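Chloro for Methoxy on a Benzothiazole Benzamide Scaffold

This account rests on a few compounds, and the source may have more. Where it says the series, first, only, none or still open, it means among the compounds named here.

Compound 1 `O=C(Nc1ccc(Cl)c(-c2nc3ccccc3s2)c1)c1cc([N+](=O)[O-])ccc1Cl` gives > 25000 nM, a limit of the assay.
Compound 2 `COc1ccc(-c2nc3ccccc3s2)cc1NC(=O)c1cc([N+](=O)[O-])ccc1Cl` gives > 25000 nM, again a limit.
Compound 3 `COc1ccc(NC(=O)c2cc([N+](=O)[O-])ccc2Cl)cc1-c1nc2ccccc2s1` gives > 25000 nM, also a limit.

All three were tested in an ADME assay on HEK293 cells (Homo sapiens) for cytotoxicity, with a stated time of 72 h (on this read-out higher numbers stand for an effect only at larger amounts of compound and lower numbers for an effect already at smaller amounts), and none reached a readable number. What is known is summed up in one line: the limit of > 25000 nM in this assay, at which 3 of the 3 values shown sit. Between compound 3 and compound 1 a single group is exchanged, (chloro in place of methoxy on an aromatic carbon), and the step this made is a step that the two limits leave unreadable from compound 3 to compound 1.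

Compound 4 `O=C(Nc1cc(-c2nc3ccccc3s2)ccc1Cl)c1cc([N+](=O)[O-])ccc1Cl` has not yet been measured. It relates to compound 2 through the same kind of change, (chloro in place of methoxy on an aromatic carbon), but the surroundings differ: in compound 2 the group sits ortho to a large group and para to a 1,3-benzothiazol-2-yl group, whereas in compound 3 it sits ortho to the 1,3-benzothiazol-2-yl group and para to a large group. Compound 2 and compound 3 are built from the same atoms joined differently, and the difference between the two cores is not broken down here.

In this assay the expected step is a step that the limit leaves unreadable from compound 2 to compound 4, resting on the fact that compound 2 shows only a limit and that the earlier exchange was unreadable because of the limit of > 25000 nM in this assay, at which 3 of the 3 values shown sit. Compound 4 is therefore expected to give about 30000 nM, most likely again reported only as a limit, with a plausible range from 15000 nM to 60000 nM.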

Compound 4, half-maximal effective concentration: > 25000 nM
Compound 4 was reported as a limit; the forecaster's own chance of this, stated with the estimate: 80%; the middle value is on the limit's open side.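

In this assay compound 4 gives > 25000 nM as a limit of the assay, not as a number. Compound 2 also stands only at a limit, so no step can be read for chloro in place of methoxy between compound 2 and compound 4: the limit of > 25000 nM in this assay, at which 4 of the 4 values shown sit.

The compounds shown leave open whether chloro in place of methoxy changes the half-maximal effective concentration in either direction.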